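This account rests on a few compounds, and the source may have more. Where it says the series, first, only, none or still open, it means among the compounds named here.

Measured compounds in a functional assay on DU-145 cells (Homo sapiens) for antiproliferative activity, read by MTT assay, with a stated time of 48 h; on this read-out lower numbers stand for stronger inhibition and higher numbers for weaker inhibition:
compound 1 `C/C(=C\CC/C(C)=C/CC[C@@H]1[C@@]2(C)CCC(=O)C(C)(C)[C@H]2CC[C@@]1(C)O)CC/C=C(\C)C(=O)OCc1cn(-c2cccc(O)c2)nn1`: 28400 nM
compound 2 `C/C(=C\CC/C(C)=C/CC[C@@H]1[C@@]2(C)CCC(=O)C(C)(C)[C@H]2CC[C@@]1(C)O)CC/C=C(\C)C(=O)OCc1cn(-c2ccccc2)nn1`: 95500 nM
compound 3 `C/C(=C\CC/C(C)=C/CC[C@@H]1[C@@]2(C)CCC(=O)C(C)(C)[C@H]2CC[C@@]1(C)O)CC/C=C(\C)C(=O)OCc1cn(-c2ccc(C)cc2)nn1`: a limit, > 150000 nM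

Compound 2 gives the higher of the two numbers, its nearest neighbour being compound 1, reached by a 3.4-fold higher number from compound 1 to compound 2 (0.53 log units; beyond the scatter). For compound 3 the assay reports only a limit, > 150000 nM. Compound 4 `C/C(=C\CC/C(C)=C/CC[C@@H]1[C@@]2(C)CCC(=O)C(C)(C)[C@H]2CC[C@@]1(C)O)CC/C=C(\C)C(=O)OCc1cn(-c2ccc(Cl)cc2)nn1` is the next member to be measured in this assay. Its change from compound 2 is chloro in place of hydrogen on an aromatic carbon, on an aromatic carbon of a six-membered aromatic ring of carbon only. Going by the values given here, the one measured step that bears on it is an at least 1.5-fold higher number from compound 2 to compound 3 (0.19 log units; that floor lies within the scatter), a methyl entering on an aromatic carbon, which ends at the limit of > 150000 nM in this assay, at which 1 of the 3 values shown sits. The step of an at least 5.2-fold higher number from compound 1 to compound 3 (0.72 log units; beyond the scatter) is larger but combines two changes and is less telling. For compound 4 a small rise of about a 1.4-fold higher number from compound 2 to compound 4 (0.13 log units; within the scatter) is therefore expected, possibly not beyond the scatter, with a real chance that only a limit is returned. Compound 4 is estimated at 130000 nM, range 55000 nM to 300000 nM.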

Compound 4, half-maximal inhibitory concentration: > 150000 nM
Compound 4 was reported as a limit; the forecaster's own chance of this, stated with the estimate: 40%; middle value at least 1.1-fold (0.06 log units) away from the limit.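

In this assay, chloro in place of hydrogen on the phenyl, para to a large group, gives an at least 1.5-fold higher number from compound 2 to compound 4 (0.19 log units; that floor lies within the scatter), so a second group at this place, after the methyl of compound 3, also returns only a limit and no number. Compound 3 and compound 4 cannot be ranked against each other, since the step between them cannot be read with both reported as limits: the limit of > 150000 nM in this assay, at which 2 of the 4 values shown sit. Swapping the aryl group gives an at least 5.2-fold higher number from compound 1 to compound 4 (0.72 log units; beyond the scatter), which matches what compound 3 showed and leaves the 3-hydroxyphenyl of compound 1 as the one shown to stand beyond the scatter from the others.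

As far as these compounds go, whether any group para to a large group can lower the number stays open, for example a hydroxy, an amine or a carboxylic acid. How far compound 4 lies past its limit is also unknown.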